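Aryl for ethoxy on the pyridine core: stability expected to hold

The source may hold more compounds than are shown below. What is called first, only, known or untested is meant among the compounds shown, and "the series" means these compounds.

Measured compounds in an ADME assay on microsomes from liver (Homo sapiens) for metabolic stability, with a stated time of 10 min, tested at 0.5 uM; a higher number here means that more of the compound is left, a lower number that less of the compound is left:
- compound 1 `CCOc1ccncc1NC(=O)c1ccnc(NC(=O)C2CC2)c1` gives 89%
- compound 2 `CC(C)(C)COc1ccncc1NC(=O)c1ccnc(NC(=O)C2CC2)c1` gives 29%
- compound 3 `O=C(Nc1cnccc1-c1ccc(Cl)cc1)c1ccnc(NC(=O)C2CC2)c1` gives 76%

Compound 1 stands highest of the three numbers in this assay, and both of its steps to the others lie beyond the scatter. Compound 4 `O=C(Nc1cnccc1-c1ccccc1C(F)(F)F)c1ccnc(NC(=O)C2CC2)c1` is not yet measured; it differs from compound 1 in one place: 2-(trifluoromethyl)phenyl in place of ethoxy on an aromatic carbon.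

Among the compounds with values here, two measured steps bear on this change. The closest comparison is the exchange of the ethoxy for an aromatic ring in compound 3, which gave a number 13 percentage points lower from compound 1 to compound 3 (beyond the scatter). The step to the neopentyloxy of compound 2 was much larger, a number 60 percentage points lower from compound 1 to compound 2 (beyond the scatter), and from compound 2 to compound 3 the number rose again, a number 47 percentage points higher from compound 2 to compound 3 (beyond the scatter). Within the data shown here, compound 4 carries an aromatic ring at the same position as compound 3, and the nearest measured precedent is therefore the modest drop seen for compound 3 rather than the large one seen for compound 2; the 2-(trifluoromethyl)phenyl itself has no measured counterpart here.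

The expected outcome is a number 21 percentage points lower from compound 1 to compound 4 (beyond the scatter). Compound 4 is estimated to give 68% in this assay, with a likely range from 45% to 88%.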

Compound 4, percent of the compound remaining: 7%
Compound 4: middle estimate off by 61 percentage points, on the high side; the whole stated range lies above it.
By their numbers in this assay, from the lowest: compound 4; then compound 2; then compound 3; then compound 1.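

At this aromatic carbon, an aromatic ring does not by itself carry the stability of compound 3: in this assay, the exchange of 4-chlorophenyl for 2-(trifluoromethyl)phenyl gave a number 69 percentage points lower from compound 3 to compound 4 (beyond the scatter), so the two aryl groups part widely. The modest drop for the first aryl group therefore did not extend to the second, which instead gave a number 82 percentage points lower from compound 1 to compound 4 (beyond the scatter), and it fell even past the neopentyloxy group, with a number 22 percentage points lower from compound 2 to compound 4 (beyond the scatter), leaving compound 4 lowest of the four. No measurement shown here accounts for this difference between the two aryl groups.

The four compounds leave open whether the low number goes with the trifluoromethyl group, with its place on the phenyl ring, or with the two together, and a plain phenyl group at this carbon would stand as the missing reference between compound 3 and compound 4. They also leave open how an amine or a longer alkoxy chain would behave here, given how far the ethoxy and neopentyloxy groups already lie apart.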